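The source may report more compounds than this note shows. Statements on the series, on what has been measured and on what is new or still open speak of the compounds shown alone.

Compound 1 `COc1cc2c(Oc3ccc(NC(=O)c4cc(-c5ccccc5)ccn4)cc3F)ccnc2cc1OCCCN1CCN(C)CC1` gives 150 nM in a functional assay on MKN-45 cells (Homo sapiens) for cytotoxicity, read by MTT assay, with a stated time of 72 h; a lower number here means a stronger inhibitor, a higher number a weaker inhibitor. Compound 2 `COc1cc2c(Oc3ccc(NC(=O)c4cc(-c5ccccc5C)ccn4)cc3F)ccnc2cc1OCCCN1CCN(C)CC1` differs from it by methyl in place of hydrogen on an aromatic carbon, and the measured step is a 1.6-fold higher number from compound 1 to compound 2 (0.20 log units; within the scatter). Compound 3 `COc1cc2c(Oc3ccc(NC(=O)c4cc(-c5ccccc5)ccn4)cc3F)ccnc2cc1OCCCN1CCCCC1` has a different core; how the two cores differ is piperidin-1-yl in place of 4-methylpiperazin-1-yl on a saturated chain carbon, three bonds along the chain from an oxygen on an aromatic ring, and the step is a 1.8-fold higher number from compound 1 to compound 3 (0.26 log units; within the scatter). In this assay compound 3 gives 270 nM, and compound 2 gives 240 nM. Compound 4 `COc1cc2c(Oc3ccc(NC(=O)c4cc(-c5ccc(C)cc5)ccn4)cc3F)ccnc2cc1OCCCN1CCCCC1` differs from compound 3 by methyl in place of hydrogen on an aromatic carbon, the same kind of change as from compound 1 to compound 2, though there the methyl sits ortho to a large group and here para to a large group. The step from compound 3 is expected to be a 1.5-fold higher number from compound 3 to compound 4 (0.17 log units; within the scatter), a little larger than the earlier one because a 1.6-fold higher number from compound 1 to compound 2 (0.20 log units; within the scatter) sat within the scatter. Compound 4 is expected to give about 400 nM, plausibly between 170 nM and 950 nM.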

Compound 4, half-maximal inhibitory concentration: 1670 nM
The estimate for compound 4 lay 4.2-fold (0.62 log units) below the measured number; measured number above the stated range.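

In this assay a methyl para to a large group gives a 6.2-fold higher number from compound 3 to compound 4 (0.79 log units; beyond the scatter) and so the change does not carry over at one size between these two cores: the same change on two cores in this assay, a 1.6-fold higher number (0.20 log units; within the scatter) from compound 1 to compound 2 and a 6.2-fold higher number (0.79 log units; beyond the scatter) from compound 3 to compound 4, 3.9-fold (0.59 log units) apart, beyond the scatter of two such steps. This rests on a single pair of steps and sets no rule for the series. The two pairs also differ in where the methyl stands on the phenyl ring, and these data do not separate that difference from the change of core.

Still open, as far as these compounds go, is what a 4-methylphenyl group does on the core of compound 1, which would help to separate the two. Also open, from the compounds shown here alone, is whether a chlorine atom or a methoxy group in the methyl's place would behave the same way on either core.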